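The source may hold more compounds than are shown below. What is called first, only, known or untested is meant among the compounds shown, and "the series" means these compounds.

Compound 2 `CCOC(=O)c1cn(C[C@H]2O[C@@H](n3cc(C)c(=O)[nH]c3=O)[C@H](SCC)[C@@H]2SCC)nn1` carries an ethoxycarbonyl group on the shared core. In a functional assay on HepG2 cells (Homo sapiens) for cytotoxicity, read by MTT assay, with a stated time of 72 h (on this read-out higher numbers stand for an effect only at larger amounts of compound and lower numbers for an effect already at smaller amounts), compound 2 gives only a limit, >= 100000 nM, as one of the values at the limit of >= 100000 nM in this assay, at which 1 of the 2 values shown sits. Compound 1 `CCS[C@@H]1[C@H](SCC)[C@@H](Cn2cc(-c3ccc(OC)cc3)nn2)O[C@H]1n1cc(C)c(=O)[nH]c1=O`, which bears 4-methoxyphenyl at the same place, gives in this assay 22800 nM. Going by the values given here, the single measured step, an at least 4.3-fold higher number from compound 1 to compound 2 (0.64 log units; beyond the scatter), is the only guide available. Compound 3 `CCS[C@@H]1[C@H](SCC)[C@@H](Cn2cc(-c3cccs3)nn2)O[C@H]1n1cc(C)c(=O)[nH]c1=O` has not been measured in this assay; it differs from compound 2 by thiophen-2-yl in place of ethoxycarbonyl on an aromatic carbon. This change reverses the kind of exchange seen in an at least 4.3-fold higher number from compound 1 to compound 2 (0.64 log units; beyond the scatter), putting a five-membered aromatic ring back where the ethoxycarbonyl group stood, and the step to compound 3 is therefore expected to run toward lower numbers, roughly matching that step in size: an at least 3.3-fold lower number from compound 2 to compound 3 (0.52 log units; beyond the scatter). Compound 3 is estimated to give 30000 nM, with a range from 10000 nM to 100000 nM.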

Compound 3, half-maximal effective concentration: >= 100000 nM
Compound 3: a limit, no number (the forecaster's own chance of this, stated with the estimate: 30%); middle value at least 3.3-fold (0.52 log units) away from the limit.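

Thiophen-2-yl on this aromatic carbon gives an at least 4.3-fold higher number from compound 1 to compound 3 (0.64 log units; beyond the scatter), so an aromatic ring at this place is not enough on its own to keep a readable effect in this assay. The result for compound 3 is a limit and not a number, so the step between the two limits cannot be read, and ethoxycarbonyl and thiophen-2-yl cannot be ranked against each other. Of the three groups shown at this place, only 4-methoxyphenyl gives a number, while the other two stop at the same limit: the limit of >= 100000 nM in this assay, at which 2 of the 3 values shown sit.

Still open, from the compounds shown here alone, is whether the difference lies with the methoxy group or with the phenyl ring that carries it, which plain phenyl or 4-hydroxyphenyl would help to separate. Going by these compounds, how an amine or a carboxylic acid would read at this carbon also remains open.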